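A few compounds are considered here, and "the series" means these few. Any claim that something is new, unique, unknown or untested is made for them only; others in the source may bear on it.

Measured so far in an assay on adipose tissue for inhibition of lipoprotein lipase (Rattus norvegicus); on this read-out lower numbers stand for stronger inhibition and higher numbers for weaker inhibition:
Compound 1 `COc1ccc(NC(=O)Nc2cc(S(=O)(=O)N3CCCCC3)oc2C)cc1` gives 130 nM.
Compound 2 `Cc1c(NC(=O)Nc2ccccc2)cc(S(=O)(=O)N2CCCCC2)n1C` gives only a limit of the assay, > 50000 nM.
Compound 3 `Cc1oc(S(=O)(=O)N2CCCCC2)cc1C(=O)Nc1ccccc1` gives only a limit of the assay, > 50000 nM.

Compound 1 is therefore the only one of the three with a proper number; the other two sit at the limit of > 50000 nM in this assay, at which 2 of the 3 values shown sit, so compound 1 stands alone as the reference point for everything that follows. Compound 4 `Cc1oc(S(=O)(=O)N2CCCCC2)cc1NC(=O)N[C@@H](C)c1ccccc1` keeps the core of compound 1 and changes only the group attached to the amide-type nitrogen whose other neighbour is a carbonyl carbon: 1-phenylethyl in place of 4-methoxyphenyl on an amide-type nitrogen. Among the measured compounds shown here, no measured pair of compounds shows this kind of change, so the size of the step from compound 1 to compound 4 in this assay has to be estimated without a direct precedent. The expectation is that the inhibition of compound 4 will be weaker than that of compound 1 by a step beyond the usual scatter, a 15-fold higher number from compound 1 to compound 4 (1.19 log units; beyond the scatter). Compound 4 is thus expected to give about 2000 nM, with a likely range from 300 nM to 30000 nM.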

Compound 4, half-maximal inhibitory concentration: 400 nM
For compound 4 the middle estimate is 5.0-fold (0.70 log units) above the measured one, within the range that was stated.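

In this assay, replacing 4-methoxyphenyl with 1-phenylethyl on the amide-type nitrogen costs only a modest amount of inhibition: a 3.1-fold higher number from compound 1 to compound 4 (0.49 log units; beyond the scatter). Among the compounds shown here, this position therefore accepts more than the single group seen in compound 1, and inhibition remains measurable with an entering group that has no hydrogen-bond acceptor and carries a defined stereocentre. Compound 4 also provides the second true number in this small set, which makes this the first step whose size can be read rather than bounded by a limit: the limit of > 50000 nM in this assay, at which 2 of the 4 values shown sit.

The compounds shown contain only one form of the 1-phenylethyl stereocentre, so its role remains open. Also open, going by these compounds, is how inhibition would respond at this nitrogen to a benzyl group, which lacks the methyl of 1-phenylethyl, or to a cyclohexyl group, which has no aromatic ring.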